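Series notes: anilino-substituted core, mitochondrial activation

The compounds below may be only part of what the source reports. "The series", "measured", "known", "first", "only" and "open" are said of these compounds alone.

Measured so far:
compound 1, `CCCCOc1cccc(Nc2nc3nonc3nc2O)c1`, 2300 nM in an assay on mitochondria from L6 cells (Rattus norvegicus) for activation, with a stated time of 90 min; a higher number here means that more compound is needed for the effect, a lower number that less compound is needed
compound 2, `Oc1nc2nonc2nc1Nc1ccc(SC(F)(F)F)cc1`, 1400 nM in this assay

Two compounds carry the shared core and differ only in the substituent on the anilino ring. In this assay compound 2 gives 1400 nM, the lowest of the two numbers, and compound 1 gives 2300 nM; the gap between them is within the scatter, so no order between compound 1 and compound 2 can be read from these two values.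

Compound 3, `Oc1nc2nonc2nc1Nc1ccccc1`, is not yet measured. It differs from compound 2 in one place: hydrogen in place of (trifluoromethyl)sulfanyl on an aromatic carbon. Going by the values given here, no step between measured compounds covers a change of this kind, so the expectation rests on the one measured pair only. The number for compound 3 is expected to rise, by a step of a 3.2-fold higher number from compound 2 to compound 3 (0.51 log units; beyond the scatter) that lies beyond the scatter. Compound 3 is therefore estimated at 4500 nM, with a range of 1500 nM to 14000 nM.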

Compound 3, half-maximal effective concentration: 66700 nM
Compound 3: middle estimate off by 15-fold (1.17 log units), on the low side; the measured number lies above the stated range.
By their numbers in this assay, from the lowest: compounds 2 and 1 (each within the scatter of the next); then compound 3.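

Hydrogen in place of (trifluoromethyl)sulfanyl on an aromatic carbon gives a 48-fold higher number from compound 2 to compound 3 (1.68 log units; beyond the scatter) in this assay and hydrogen in place of butoxy gives a 29-fold higher number from compound 1 to compound 3 (1.46 log units; beyond the scatter) in the same direction. The anilino ring without a substituent therefore stands well apart from both substituted compounds, and across these three compounds having a substituent on that ring matters more than which of the two it is. Nothing on hand accounts for the size of these steps.

On these data alone, it remains open whether a small group such as fluorine or methyl, or an amine or a carboxylic acid, on the same aromatic carbon would keep the number near that of compound 2. As far as these compounds go, it also remains open how a chain longer than butoxy would shift the number.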